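A Smaller Amine Tail on a Bradykinin Receptor Antagonist

The source may hold more compounds than are shown below. What is called first, only, known or untested is meant among the compounds shown, and "the series" means these compounds.

Compound 1 `CCN(CC)CCN1CCN(C(=O)COCCN(C)S(=O)(=O)c2c(C)cc(OC)cc2C)CC1` gives 7.8 in a functional assay on Umbilical vein for antagonist activity at B1 bradykinin receptor (Homo sapiens), using Schild analysis, with a stated time of 30 min; a lower number here means a less potent compound, a higher number a more potent compound, by a factor of ten per unit of this negative logarithm.
Compound 2 `COc1ccc(S(=O)(=O)N(C)CCOCC(=O)N(C)Cc2ccc(C3=NCCN3)cc2)c(C)c1` gives 8.6 in this assay.

Of these two values, compound 1 has the lower one; compound 2 stands higher, beyond the usual scatter. Compound 3 `COc1cc(C)c(S(=O)(=O)N(C)CCOCC(=O)N2CCN(CCN(C)C)CC2)c(C)c1` has not yet been measured. It differs from compound 1 in one place only: dimethylamino in place of diethylamino on a saturated chain carbon, two bonds along the chain from an amine nitrogen in a ring. Within the data shown here, no measured pair shows this change, so the data give no size for it. The shared core is untouched and the change is small, so a step from compound 1 to compound 3 of a number 0.10 log units lower from compound 1 to compound 3 (within the scatter) is expected, within the scatter. Compound 3 is estimated at 7.7, with a range from 7.2 to 8.3.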

Compound 3, negative logarithm of the antagonist equilibrium constant: 7.4
Compound 3: the middle estimate sits 0.30 log units above what was measured; low and high end bracket the measured number.
By their numbers in this assay, from the lowest: compound 3; then compound 1; then compound 2.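

In this assay, dimethylamino in place of diethylamino at this position gives a number 0.40 log units lower from compound 1 to compound 3 (beyond the scatter), a modest step. The potency of this compound series therefore responds to a change at this chain end, even one this small, and here the smaller amine gives the lower number. The data offer no explanation for this step. Still open, from the compounds shown here alone, is how a pyrrolidine or a morpholine ring at this position would compare, and whether a longer chain leading to the amine would change the number.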